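The source may report more compounds than this note shows. Statements on the series, on what has been measured and on what is new or still open speak of the compounds shown alone.

For the measured compounds named here, in a functional assay on MDA-MB-231 cells (Homo sapiens) for inhibition, read by sulforhodamine B assay, tested at 10 uM (a lower number here means less inhibition, a higher number more inhibition at the concentration tested (going by the name of the read-out)), compound 2 `CN(C)c1ccc(C2CC(c3ccc(-n4ccnc4)cc3)=NN2C(=O)c2ccc(C(F)(F)F)cc2)cc1` gives 17.9%, the lower of the two numbers measured so far, while compound 1 `CN1CCN(c2ccc(C3=NN(S(=O)(=O)c4ccc(C#N)cc4)C(c4ccc(N(C)C)cc4)C3)cc2)CC1` gives 99.8%, a gap that lies beyond the scatter. Compound 3 `CN(C)c1ccc(C2CC(c3ccc(-n4ccnc4)cc3)=NN2S(=O)(=O)c2ccc(C#N)cc2)cc1` differs from compound 2 in one place: (4-cyanophenyl)sulfonyl in place of (4-(trifluoromethyl)phenyl)carbonyl on an amine nitrogen in a ring. Going by the values given here, no step between measured compounds is available, so the size of this change must be judged indirectly. A rise beyond the scatter is expected, because compound 1 carrying the same (4-cyanophenyl)sulfonyl group gives 99.8%, although compound 1 also differs elsewhere. Compound 3 is therefore expected to give 60%, between 25% and 95%, a step of a number 42.1 percentage points higher from compound 2 to compound 3 (beyond the scatter).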

Compound 3, a percentage reported as inhibition, at one concentration (the size of the read-out at that concentration, not a potency): 7.1%
Beside the measured number, compound 3's estimate is 52.9 percentage points above it, outside the stated range (below it).
By their numbers in this assay, from the lowest: compound 3; then compound 2; then compound 1.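

With 1H-imidazol-1-yl held in place, the swap on the ring nitrogen gives a number 10.8 percentage points lower from compound 2 to compound 3 (beyond the scatter) and so moves the inhibition only modestly, with (4-cyanophenyl)sulfonyl not sufficient for high inhibition in this pair. With (4-cyanophenyl)sulfonyl held in place, 1H-imidazol-1-yl replacing 4-methylpiperazin-1-yl on the aromatic carbon gives a number 92.7 percentage points lower from compound 1 to compound 3 (beyond the scatter) and is by far the larger change. No measured evidence explains either step. Still open, on these data alone, is how 4-methylpiperazin-1-yl behaves alongside (4-(trifluoromethyl)phenyl)carbonyl, and whether a morpholine ring on that aromatic carbon would match it.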